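Swapping furan-3-yl for pyrrole on the shared core

A few compounds are considered here, and "the series" means these few. Any claim that something is new, unique, unknown or untested is made for them only; others in the source may bear on it.

Values measured in a functional assay on A-375 cells (Homo sapiens) for antiproliferative activity (on this read-out lower numbers stand for stronger inhibition and higher numbers for weaker inhibition), are:

- compound 1 `O=C(Nc1ccc(-c2cccnc2)cc1)C1CCCN(Cc2ccc(F)c(F)c2)C1` gives 610 nM
- compound 2 `O=C(Nc1ccc(-c2nccs2)cc1)C1CCCN(Cc2ccc(F)c(F)c2)C1` gives 240 nM
- compound 3 `O=C(Nc1ccc(-c2ccoc2)cc1)C1CCCN(Cc2ccc(F)c(F)c2)C1` gives 1290 nM

Compound 3 has the highest number of the three, which makes it the weakest inhibitor so far, and compound 1 is its nearest neighbour. The next compound, compound 4 `O=C(Nc1ccc(-c2ccc[nH]2)cc1)C1CCCN(Cc2ccc(F)c(F)c2)C1`, has 1H-pyrrol-2-yl in place of furan-3-yl on an aromatic carbon, para to a large group (1H-pyrrol-2-yl in place of furan-3-yl on an aromatic carbon).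

Only the group at this one place differs among the measured compounds, so their steps are the best guide. Changing it has had modest effects so far, as in the step of a 2.5-fold lower number from compound 1 to compound 2 (0.41 log units; beyond the scatter). Both steps that arrive at furan-3-yl raised the number, namely a 2.1-fold higher number from compound 1 to compound 3 (0.33 log units; beyond the scatter) and a 5.4-fold higher number from compound 2 to compound 3 (0.73 log units; beyond the scatter). Moving away from furan-3-yl therefore seems more likely to lower the number than to raise it, although no pyrrole has been measured here and the direction remains uncertain. In this assay, the expected change is a modest one, estimated as a 2.2-fold lower number from compound 3 to compound 4 (0.33 log units; beyond the scatter). For compound 4 the estimated value is 600 nM, with an expected range from 200 nM to 1800 nM.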

Compound 4, half-maximal inhibitory concentration: 360 nM
For compound 4 the middle estimate is 1.7-fold (0.22 log units) above the measured one, and the stated range covers the measured number.
By their numbers in this assay, from the lowest: compounds 2, 4 and 1 (each within the scatter of the next, the first and the last beyond it); then compound 3.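

In this assay, the step of a 3.6-fold lower number from compound 3 to compound 4 (0.55 log units; beyond the scatter) shows that this position can respond to a swap between two five-membered aromatic rings with the same heavy-atom count and one hetero atom each. The other two new steps, a 1.5-fold higher number from compound 2 to compound 4 (0.18 log units; within the scatter) and a 1.7-fold lower number from compound 1 to compound 4 (0.23 log units; within the scatter), lie within the scatter, so 1H-pyrrol-2-yl cannot be ranked against either 1,3-thiazol-2-yl or pyridin-3-yl, and compound 3 with furan-3-yl remains the weakest of the four. The swap from compound 3 to compound 4 alters the hetero atom, the point of attachment and the hydrogen-bond donor and acceptor counts all at once, so this single step cannot assign the difference to any one of them.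

Furan-2-yl would keep the oxygen while matching the attachment point of the pyrrole, and 1-methyl-1H-pyrrol-2-yl would replace the ring hydrogen on nitrogen with a methyl group, but neither is among the compounds shown, so those two questions stay open. No measurement offered here explains why these groups differ.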